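Swapping cyclopropylmethyl for cyclobutyl on the amine nitrogen

The source may hold more compounds than are shown below. What is called first, only, known or untested is meant among the compounds shown, and "the series" means these compounds.

Measured compounds:
- compound 1 `Cc1cc(CN(C2CCC2)C(CC(=O)O)c2ccc(Cl)cc2)ccc1OCCn1c(=O)ccn(C)c1=O`: 95 nM
- compound 2 `CCCN(Cc1ccc(OCCn2c(=O)ccn(C)c2=O)c(OC)c1)C(CC(=O)O)c1ccc(Cl)cc1`: 132 nM
- compound 3 `COc1cc(CN(CC2CC2)C(CC(=O)O)c2ccc(Cl)cc2)ccc1OCCn1c(=O)ccn(C)c1=O`: 91 nM

In an assay on CHO cells for displacement of a labelled ligand from C-X-C chemokine receptor type 3 (Homo sapiens), with a stated time of 60 min (on this read-out lower numbers stand for stronger inhibition and higher numbers for weaker inhibition), compound 3 gives the lowest of the three numbers, yet compound 1 and compound 2 both sit within the scatter of it, so no order among them can be claimed. Compound 4 `COc1cc(CN(C2CCC2)C(CC(=O)O)c2ccc(Cl)cc2)ccc1OCCn1c(=O)ccn(C)c1=O` differs from compound 3 only in cyclobutyl in place of cyclopropylmethyl on an amine nitrogen. Going by the values given here, the one single-point step measured on this nitrogen, a 1.5-fold lower number from compound 2 to compound 3 (0.16 log units; within the scatter), changed nothing beyond the scatter, and compound 1, which also carries cyclobutyl there, gives a number close to that of compound 3. The expected step is therefore a 1.0-fold higher number from compound 3 to compound 4 (0.02 log units; within the scatter), no change beyond the scatter. Compound 4 is estimated at 95 nM, within a range from 45 nM to 200 nM.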

Compound 4, half-maximal inhibitory concentration: 152 nM
Compound 4: middle estimate off by 1.6-fold (0.20 log units), on the low side, within the range that was stated.
By their numbers in this assay, from the lowest: compounds 3, 1, 2 and 4 (each within the scatter of the next).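

In this assay all three new steps stay within the scatter: the two on the amine nitrogen (a 1.7-fold higher number from compound 3 to compound 4 (0.22 log units; within the scatter) and a 1.2-fold higher number from compound 2 to compound 4 (0.06 log units; within the scatter)) and the one on the aromatic carbon (a 1.6-fold higher number from compound 1 to compound 4 (0.20 log units; within the scatter)). This nitrogen has now carried propyl, cyclopropylmethyl and cyclobutyl on the shared core with no change beyond the scatter, and methoxy in place of methyl adds none either. No measurement shown bears on why these numbers lie so close. Still open, going by these compounds, is whether an amine or a hydroxyl group at the end of a longer chain on this nitrogen would move the number beyond the scatter.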